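Removing the methoxy from the acid-bearing ring

The source may report more compounds than this note shows. Statements on the series, on what has been measured and on what is new or still open speak of the compounds shown alone.

Compound 2 `COc1cc(C(=O)O)ccc1OCCCCOc1ccc(C(=O)CC(C)C)c(O)c1C` gives 40 nM in an assay on HEK293 cells for positive allosteric modulation of metabotropic glutamate receptor 2 (Rattus norvegicus), read by thallium flux, with a stated time of 2.5 min (a lower number here means that less compound is needed, a higher number that more compound is needed for the effect), the lowest of the two numbers reported, while compound 1 `COc1cc(C(=O)O)ccc1OCCCCOc1ccc(C(=O)CC(C)(C)C)c(O)c1C` gives 47 nM; the step of a 1.2-fold lower number from compound 1 to compound 2 (0.07 log units; within the scatter) lies within the scatter. Within the data shown here, compound 3 `Cc1c(OCCCCOc2cccc(C(=O)O)c2)ccc(C(=O)CC(C)C)c1C` is reported as "not active" (no number reported) in this assay, but it differs from compound 2 in more than one place and forms no single step. Compound 4 `Cc1c(OCCCCOc2ccc(C(=O)O)cc2)ccc(C(=O)CC(C)C)c1O` differs from compound 2 in one place: hydrogen in place of methoxy on an aromatic carbon. No measured step isolates this change; the one step shown concerns the side chain and was small. Compound 3, which also lacks the methoxy, gives "not active" (no number reported), which hints at a somewhat higher number for compound 4. Compound 4 is therefore expected to give 110 nM in this assay, between 35 nM and 450 nM, an expected step of a 2.8-fold higher number from compound 2 to compound 4 (0.44 log units; beyond the scatter).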

Compound 4, half-maximal effective concentration: 122 nM
Compound 4: middle estimate off by 1.1-fold (0.04 log units), on the low side; the range from low to high includes it.
By their numbers in this assay, from the lowest: compounds 2 and 1 (each within the scatter of the next); then compound 4.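

Among these compounds, this gives the first single-change reading at this aromatic carbon, ortho to a large group and meta to a carboxy group: in this assay, hydrogen in place of methoxy produces a step beyond the scatter (a 3.1-fold higher number from compound 2 to compound 4 (0.48 log units; beyond the scatter)). Compound 4 still gives a measured number, so the methoxy is not required for activity here, although this change moves the number more than the side-chain step did (a 1.2-fold lower number from compound 1 to compound 2 (0.07 log units; within the scatter)). Nothing available explains the shift. On these data alone, whether ethoxy, chlorine or hydroxy at this carbon would match the methoxy remains open.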